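From methoxy to isopropoxy at a limit

This account rests on a few compounds, and the source may have more. Where it says the series, first, only, none or still open, it means among the compounds named here.

compound 1 `CCOC(=O)c1c(-c2cccc(OC)c2)[nH]c2cc(OC)ccc2c1=O`: > 21500 nM
compound 2 `CCOC(=O)c1c(-c2cccc([N+](=O)[O-])c2)[nH]c2cc(OC)ccc2c1=O`: > 21500 nM
compound 3 `CCOC(=O)c1c(-c2cccc(O)c2)[nH]c2cc(OC)ccc2c1=O`: > 21500 nM

In an ADME assay on BJ cells (Homo sapiens) for cytotoxicity, read by luminescence, with a stated time of 72 h (on this read-out lower numbers stand for an effect already at smaller amounts and higher numbers for an effect only at larger amounts of compound), compound 1 gives > 21500 nM as a limit and not a number. All measured compounds stand at the limit of > 21500 nM in this assay, at which 3 of the 3 values shown sit, and none has a readable value. Compound 4 `CCOC(=O)c1c(-c2cccc(OC)c2)[nH]c2cc(OC(C)C)ccc2c1=O` carries one change from compound 1: isopropyl in place of methyl on an oxygen on an aromatic ring. The nearest measured change is a step that the two limits leave unreadable from compound 1 to compound 3 and it also falls on such an oxygen. Alongside it stands a step that the two limits leave unreadable from compound 1 to compound 2 and neither gives a size to carry over. No step beyond the scatter is therefore expected, and the estimate is a step that the limit leaves unreadable from compound 1 to compound 4 in this assay. Compound 4 is estimated at 25000 nM with an expected range of 12000 nM to 60000 nM in this reading.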

Compound 4, half-maximal effective concentration: > 21500 nM
Compound 4 was reported as a limit; the forecaster's own chance of this, stated with the estimate: 85%; the middle value does not contradict the limit.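

Among the compounds shown here, compound 1 and compound 4 both stand at a limit, and no step between them can be read. The compounds shown leave open whether any change to the shared core would give a readable value.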